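Propylsulfanyl to amino on the shared core

This account rests on a few compounds, and the source may have more. Where it says the series, first, only, none or still open, it means among the compounds named here.

Measured so far:
Compound 1 `CCCSc1nc(N)c2nc(O)n(Cc3ccccc3)c2n1`: 0.01 uM
Compound 2 `Nc1ncnc2c1nc(O)n2Cc1ccc(Cl)cc1`: 10 uM
Compound 3 `CSc1nc2c(N)ncnc2n1Cc1ccccc1`: > 10 uM

In a functional assay (spleen, spleen) for activation, with Mus musculus as the target (on this read-out higher numbers stand for an effect only at larger amounts of compound and lower numbers for an effect already at smaller amounts), compound 1 gives 0.01 uM, the lowest of the two numbers shown. Compound 2 gives 10 uM, a gap from compound 1 that lies beyond the scatter. For compound 3 only a limit is reported, > 10 uM (the limit of > 10 uM in this assay, at which 1 of the 3 values shown sits). Compound 4 `Nc1nc(N)c2nc(O)n(Cc3ccccc3)c2n1` has not been measured. Relative to compound 1, (amino in place of propylsulfanyl on an aromatic carbon). Among the compounds with values here, no step between measured compounds covers this change, so the expectation rests on compound 1 alone. The step of a 200-fold higher number from compound 1 to compound 4 (2.30 log units; beyond the scatter) is expected to be a rise beyond the scatter. Compound 4 is estimated at 2 uM, with a range from 0.3 uM to 10 uM.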

Compound 4, minimum effective concentration: 10 uM
Compound 4: middle estimate off by 5.0-fold (0.70 log units), on the low side, within the range that was stated.
By their numbers in this assay, from the lowest: compound 1; then compounds 2 and 4 (each within the scatter of the next).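

In this assay, within the data shown here, amino in place of propylsulfanyl gives a 1000-fold higher number from compound 1 to compound 4 (3.00 log units; beyond the scatter), the first step that changes one place alone. The position between two ring nitrogen atoms therefore strongly affects the read-out on the shared core, and amino there does not retain the low number of compound 1. The number reached lies at the figure of the assay's limit: the limit of > 10 uM in this assay, at which 1 of the 4 values shown sits.

Open, from the compounds shown here alone, is whether propoxy, propylamino or butylsulfanyl at this position would retain that low number. Also open, going by these compounds, is whether the sulfur or the chain matters more.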